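A few compounds are considered here, and "the series" means these few. Any claim that something is new, unique, unknown or untested is made for them only; others in the source may bear on it.

Measured in an assay on HEK293 cells for displacement of a labelled ligand from adenosine receptor A1 (Homo sapiens), read by scintillation counting, with a stated time of 60 min; a lower number here means a stronger inhibitor, a higher number a weaker inhibitor:
- compound 1 `N#Cc1sc(=S)n(-c2ccccc2)c1/N=C/c1ccc(F)cc1`: 0.00063 nM
- compound 2 `CCn1c(/N=C/c2ccc(Cl)cc2)c(C#N)sc1=S`: 19.8 nM
- compound 3 `CCCCn1c(/N=C/c2ccc(Cl)cc2)c(C#N)sc1=S`: 24600 nM

Compound 3 stands at the highest number of the three in this assay; its nearest neighbour is compound 2, and compound 1 lies far below both. Among the measured compounds shown here, the one step between two measured compounds that differ in one place runs from compound 2 to compound 3: a 1200-fold higher number from compound 2 to compound 3 (3.09 log units; beyond the scatter). That step concerns the group on the aromatic nitrogen of the shared core, which is also where compound 4 `N#Cc1sc(=S)n(-c2ccccc2)c1/N=C/c1ccc(Cl)cc1` differs from compound 3: phenyl in place of butyl on an aromatic nitrogen. Compound 4 carries the same group on that nitrogen as compound 1, and it carries the same chloro-substituted aryl on the imine as compound 2 and compound 3. For the measured compounds named here, no measured step isolates the exchange of butyl for phenyl on this nitrogen, so the expectation rests on compound 1 being the lowest number seen and on the large step already observed at this nitrogen. For compound 4 the number in this assay is expected to fall far below compound 3, a step of about a 4900000-fold lower number from compound 3 to compound 4 (6.69 log units; beyond the scatter), estimated at 0.005 nM with a range from 0.0003 nM to 0.1 nM.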

Compound 4, inhibition constant: 413 nM
For compound 4 the middle estimate is 83000-fold (4.92 log units) below the measured one; the whole stated range lies below it.
By their numbers in this assay, from the lowest: compound 1; then compound 2; then compound 4; then compound 3.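

With the chloro-substituted aryl held fixed, phenyl on the aromatic nitrogen does not give the lowest number: a 60-fold lower number from compound 3 to compound 4 (1.77 log units; beyond the scatter) in this assay recovers only part of the loss seen with butyl, and a 21-fold higher number from compound 2 to compound 4 (1.32 log units; beyond the scatter) leaves phenyl short of ethyl. The order at this nitrogen therefore runs ethyl, phenyl, butyl, so it does not follow chain length alone. With phenyl held fixed, chloro in place of fluoro on the aromatic carbon gives a 660000-fold higher number from compound 1 to compound 4 (5.82 log units; beyond the scatter) and is the largest step shown, so the very low number of compound 1 cannot be credited to phenyl alone.

Open, from the compounds shown here alone, is whether fluoro in place of chloro has a similar effect with ethyl or butyl on the nitrogen. Also open, going by these compounds, is how a propyl chain or a benzyl group would fall in this order. No measured evidence bears on the cause of these steps.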